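The source may hold more compounds than are shown below. What is called first, only, known or untested is meant among the compounds shown, and "the series" means these compounds.

Measured compounds in a functional assay on HT-29 cells (Homo sapiens) for cytotoxicity, read by sulforhodamine B assay; on this read-out lower numbers stand for stronger inhibition and higher numbers for weaker inhibition:
- compound 1, `C=C1[C@@H](OC(C)=O)C[C@@H]2[C@](C)(CO[Si](C)(C)C(C)(C)C)[C@H](OC(C)=O)CC[C@@]2(C)[C@@H]1C[C@@H](Nc1ccc(OC)cc1)C1=CCOC1=O`: 5370 nM
- compound 2, `C=C1[C@@H](OC(C)=O)C[C@@H]2[C@](C)(CO[Si](C)(C)C(C)(C)C)[C@H](OC(C)=O)CC[C@@]2(C)[C@@H]1C[C@@H](Nc1cccc(F)c1)C1=CCOC1=O`: 4520 nM
- compound 3, `C=C1[C@@H](OC(C)=O)C[C@@H]2[C@](C)(CO[Si](C)(C)C(C)(C)C)[C@H](OC(C)=O)CC[C@@]2(C)[C@@H]1C[C@@H](Nc1ccc(F)cc1)C1=CCOC1=O`: 4940 nM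

All three share the same core and differ only in the aryl group on the amine nitrogen. Compound 3 stands within the scatter of both neighbours: the step of a 1.1-fold lower number from compound 1 to compound 3 (0.04 log units; within the scatter) and the step of a 1.1-fold higher number from compound 2 to compound 3 (0.04 log units; within the scatter) are each too small to separate the compounds. The step of a 1.2-fold lower number from compound 1 to compound 2 (0.07 log units; within the scatter) likewise stays within the scatter, so nothing in this set so far shows that swapping one aryl substituent for another moves the number in this assay.

Compound 4, `C=C1[C@@H](OC(C)=O)C[C@@H]2[C@](C)(CO[Si](C)(C)C(C)(C)C)[C@H](OC(C)=O)CC[C@@]2(C)[C@@H]1C[C@@H](Nc1ccc(Br)cc1)C1=CCOC1=O`, is the next member. Its change against compound 3 is bromo in place of fluoro on an aromatic carbon. Within the data shown here, no measured step here exchanges one halogen for another; the closest precedent is the step of a 1.1-fold lower number from compound 1 to compound 3 (0.04 log units; within the scatter), which replaces methoxy by fluoro at the same position and stays within the scatter. On that basis the expected step of a 1.0-fold lower number from compound 3 to compound 4 (0.00 log units; within the scatter) is not beyond the scatter. Compound 4 is therefore estimated at 4900 nM in this assay, with a range of 2400 nM to 10000 nM, essentially unchanged from compound 3.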

Compound 4, half-maximal inhibitory concentration: 4590 nM
For compound 4 the middle estimate is 1.1-fold (0.03 log units) above the measured one, and the stated range covers the measured number.
By their numbers in this assay, from the lowest: compounds 2, 4, 3 and 1 (each within the scatter of the next).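

In this assay the exchange of one halogen for another on an aromatic carbon para to a large group gives a 1.1-fold lower number from compound 3 to compound 4 (0.03 log units; within the scatter) and so does not separate 4-bromophenyl from 4-fluorophenyl. The comparisons with the other two aryl groups read the same way: a 1.0-fold higher number from compound 2 to compound 4 (0.01 log units; within the scatter) for 4-bromophenyl in place of 3-fluorophenyl on the amine nitrogen, and a 1.2-fold lower number from compound 1 to compound 4 (0.07 log units; within the scatter) for bromo in place of methoxy, so the halogen exchange adds a further substituent type to a set in which every pair lies within the scatter. No independent measurement is available that would account for this flat picture.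

The aryl groups shown carry only a single fluoro, bromo or methoxy group, so it remains open whether an amine, a carboxylic acid or a nitrile on the same ring, or an aliphatic chain in place of the phenyl ring on the nitrogen, would move the number in this assay beyond the scatter. Also open, on these data alone, is how far the number depends on the shared core, since the silyl ether and both acetates stay the same in all four compounds, and a free hydroxyl at any of these places would test that.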